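The compounds below may be only part of what the source reports. "The series", "measured", "known", "first", "only" and "open" are said of these compounds alone.

Values measured in a functional assay on A549 cells (Homo sapiens) for antiproliferative activity, read by MTT assay, with a stated time of 72 h (a higher number here means a weaker inhibitor, a lower number a stronger inhibitor), so far:
compound 1 `CCn1cc(C(=O)O)c(=O)c2cc(F)c(N3CCN(C(=N)NS(=O)(=O)c4ccc(C(F)(F)F)cc4)CC3)cc21` gives 71 nM
compound 2 `Cc1ccc(S(=O)(=O)NC(=N)N2CCN(c3cc4c(cc3F)c(=O)c(C(=O)O)cn4C3CC3)CC2)cc1` gives 71 nM
compound 3 `CCn1cc(C(=O)O)c(=O)c2cc(F)c(N3CCN(C(=N)NS(=O)(=O)c4cccc(Cl)c4)CC3)cc21` gives 71 nM

At 71 nM in this assay compound 3 stands level with compound 1 and compound 2 at the digits given. Compound 4 `N=C(NS(=O)(=O)c1cccc(Cl)c1)N1CCN(c2cc3c(cc2F)c(=O)c(C(=O)O)cn3C2CC2)CC1` keeps the 3-chlorophenyl on the sulfonyl sulfur of compound 3 and differs in one place, counted as cyclopropyl in place of ethyl on an aromatic nitrogen and amounting to cyclopropyl in place of ethyl on an aromatic nitrogen.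

Among the measured compounds shown here, no measured pair isolates this exchange. For the measured compounds named here, the only single-place step on hand, no change at the digits printed from compound 1 to compound 3 (within the scatter) for the group on the sulfonyl sulfur, stays within the scatter and bears on the exchange only indirectly. Closer evidence comes from the values themselves. Compound 2 carries cyclopropyl on that nitrogen, together with a different group on the sulfonyl sulfur, and gives 71 nM in this assay while compound 1 with ethyl gives 71 nM at the same digits. Neither comparison offers a reason to expect a move in either direction, so no step beyond the scatter is expected in this assay here.

The estimated step is no change at the digits printed from compound 3 to compound 4 (within the scatter) and stays within the scatter. The estimate for compound 4 is 71 nM with an expected range from 35 nM to 145 nM in this series.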

Compound 4, half-maximal inhibitory concentration: 71 nM
Compound 4: middle estimate and measured number agree at the digits printed, and the stated range covers the measured number.
By their numbers in this assay, from the lowest: compounds 1, 2, 3 and 4 (each within the scatter of the next).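

The exchange of ethyl for cyclopropyl on the aromatic nitrogen now has a matched pair of its own in this assay, and it reads no change at the digits printed from compound 3 to compound 4 (within the scatter), where the two groups could earlier be set side by side only across compounds that also differed on the sulfonyl sulfur. Among the compounds shown here, the second new pair gives no change at the digits printed from compound 2 to compound 4 (within the scatter) for 3-chlorophenyl in place of 4-methylphenyl on the sulfonyl sulfur, so an exchange at that group, earlier seen only with ethyl on the nitrogen, now also stands with cyclopropyl. Across these four compounds, neither of the two places changed has moved the number at the digits printed, and none of the four goes against this. Nothing measured here offers an explanation for this flat picture.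

The compounds shown leave open whether the same holds for a hydrogen, a longer chain such as n-butyl or a benzyl group on that aromatic nitrogen. They also leave open how the number responds when the carboxylic acid of the shared core gives way to a primary amide or an ester.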